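The source may hold more compounds than are shown below. What is called first, only, known or untested is meant among the compounds shown, and "the series" means these compounds.

Compound 1 `O=C(Nc1cc2cc[nH]c(=O)c2cc1Cl)C1CNCC1c1ccc(F)cc1` and compound 2 `O=C(Nc1cc2cc[nH]c(=O)c2cc1Cl)C1CNCC1c1ccccc1` share the same core and differ only on one ring. In a functional assay on aorta (Rattus norvegicus) for inhibition (a higher number here means a weaker inhibitor, a lower number a stronger inhibitor), compound 1 gives 160 nM and compound 2 gives 89 nM. These two values lie within the usual scatter of each other, so neither compound can be ranked above the other, and compound 2 has no measured neighbour that stands clearly apart from it.

Compound 3 `O=C(Nc1cc2cc[nH]c(=O)c2cc1Cl)C1CNCC1c1cccc(Br)c1` has not yet been measured. It differs from compound 2 by bromo in place of hydrogen on an aromatic carbon, which turns phenyl to 3-bromophenyl (bromo in place of hydrogen on an aromatic carbon).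

For the measured compounds named here, the one measured change on this ring puts hydrogen in place of fluoro. Because a 1.8-fold lower number from compound 1 to compound 2 (0.25 log units; within the scatter) stays small, no step beyond the scatter is expected in this assay, in either direction, although a single fluoro pair is a thin guide to bromo.

The estimated change is a 1.1-fold higher number from compound 2 to compound 3 (0.05 log units; within the scatter). For compound 3 the expected value is 100 nM, with an estimated range of 35 nM to 300 nM.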

Compound 3, half-maximal inhibitory concentration: 63 nM
The estimate for compound 3 lay 1.6-fold (0.20 log units) above the measured number; the measured number falls inside the stated range.
By their numbers in this assay, from the lowest: compounds 3, 2 and 1 (each within the scatter of the next, the first and the last beyond it).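

In this assay, a bromo group can sit on the aromatic carbon meta to a large group without moving the number beyond the scatter (a 1.4-fold lower number from compound 2 to compound 3 (0.15 log units; within the scatter)), so compound 3 cannot be ranked apart from compound 2, which carries plain phenyl. For the compounds shown here, changing this ring does produce a step that clears the scatter, though a modest one (a 2.5-fold lower number from compound 1 to compound 3 (0.40 log units; beyond the scatter)), and this is the first such step; it exchanges 4-fluorophenyl for 3-bromophenyl, so the group and its place on the ring change together and their separate shares cannot be read from this pair. Nothing available here bears on why these numbers fall as they do.

The compounds shown leave open how other groups at this same place, such as a methoxy group, a nitrile or an amine, would read in this assay. They also leave open how bromo and fluoro compare at one and the same place on the ring, since here the two groups sit at different places.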